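Triazole substituent swap on a shared furanone core

A few compounds are considered here, and "the series" means these few. Any claim that something is new, unique, unknown or untested is made for them only; others in the source may bear on it.

The measured compounds in this series:
- Compound 1 `CC(C)(C)c1cn(C[C@H](O)[C@H]2OC(=O)C(OCc3ccccc3)=C2OCc2ccccc2)nn1`: 54900 nM
- Compound 2 `Cc1ccc(S(=O)(=O)NCc2cn(C[C@H](O)[C@H]3OC(=O)C(OCc4ccccc4)=C3OCc3ccccc3)nn2)cc1`: 68000 nM
- Compound 3 `C[Si](C)(C)c1cn(C[C@H](O)[C@H]2OC(=O)C(OCc3ccccc3)=C2OCc2ccccc2)nn1`: 52600 nM

In a functional assay on CFPAC-1 cells (Homo sapiens) for antiproliferative activity, read by MTT assay, with a stated time of 72 h (on this read-out lower numbers stand for stronger inhibition and higher numbers for weaker inhibition), compound 3 gives the lowest of the three numbers, yet the steps of a 1.0-fold lower number from compound 1 to compound 3 (0.02 log units; within the scatter) and a 1.3-fold lower number from compound 2 to compound 3 (0.11 log units; within the scatter) are within the scatter, so no order among the three can be claimed. The unmeasured compound 4 `COc1ccc(-c2cn(C[C@H](O)[C@H]3OC(=O)C(OCc4ccccc4)=C3OCc3ccccc3)nn2)cc1` differs from compound 3 in one place: a group of 8 heavy atoms (7 carbon, 1 oxygen; one six-membered aromatic ring of carbon only) in place of a group of 4 heavy atoms (3 carbon, 1 silicon; no ring), on an aromatic carbon. Among the compounds with values here, the step that bears most on this change is the one from compound 1 to compound 2, where a group with a six-membered carbon ring replaced a small saturated group on the same aromatic carbon and gave a 1.2-fold higher number from compound 1 to compound 2 (0.09 log units; within the scatter). Exchanging small groups, as from compound 1 to compound 3, also gave a 1.0-fold lower number from compound 1 to compound 3 (0.02 log units; within the scatter). Because compound 3 gives 52600 nM and every step among the measured compounds is within the scatter, compound 4 is expected to stay near compound 3, with an estimated step of a 1.0-fold higher number from compound 3 to compound 4 (0.02 log units; within the scatter). The expected value for compound 4 in this assay is 55000 nM, within a range from 25000 nM to 120000 nM.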

Compound 4, half-maximal inhibitory concentration: 26000 nM
For compound 4 the middle estimate is 2.1-fold (0.33 log units) above the measured one, within the range that was stated.
By their numbers in this assay, from the lowest: compound 4; then compounds 3, 1 and 2 (each within the scatter of the next).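

Within the data shown here, compound 4 is the first compound in this set whose number moves beyond the scatter when the group on this aromatic carbon changes, with modest steps against all three earlier compounds (a 2.0-fold lower number from compound 3 to compound 4 (0.31 log units; beyond the scatter); a 2.1-fold lower number from compound 1 to compound 4 (0.32 log units; beyond the scatter); a 2.6-fold lower number from compound 2 to compound 4 (0.42 log units; beyond the scatter)). A six-membered aromatic ring of carbon only does not by itself go with a lower number, since compound 2 also carries one in its group and stays within the scatter of compound 1 and compound 3. Nothing available here gives a reason for the lower number of compound 4.

The compounds shown cannot separate the part played by the ring from that of its methoxy group, which a plain phenyl ring would help to settle. From the compounds shown here alone, how an amine or a carboxylic acid on that ring would compare also remains open.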